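Swapping Fluoro for Chloro on the Outer Ring

A few compounds are considered here, and "the series" means these few. Any claim that something is new, unique, unknown or untested is made for them only; others in the source may bear on it.

Three compounds share one core and differ only in the outer aromatic ring. Compound 1 `c1ccc(-c2ccc(Cn3nnc4ccccc43)cc2)cc1` carries a plain phenyl group, and in a functional assay on cells for positive allosteric modulation of metabotropic glutamate receptor 2 (Homo sapiens), read by fluorescence and calcium flux, with a stated time of 30 min (a lower number here means that less compound is needed, a higher number that more compound is needed for the effect), compound 1 gives 155 nM. Compound 2 `Fc1ccc(-c2ccc(Cn3nnc4ccccc43)cc2)c(F)c1` carries a 2,4-difluorophenyl group and gives 71 nM. Compound 3 `Fc1ccc(-c2ccc(Cn3nnc4ccccc43)cc2)c(Cl)c1` carries a 2-chloro-4-fluorophenyl group and gives 118 nM. Compound 3 thus holds the second highest of the three numbers, with compound 1 and compound 2 both sitting within the usual scatter of it. The measured steps are a 2.2-fold lower number from compound 1 to compound 2 (0.34 log units; beyond the scatter), a 1.3-fold lower number from compound 1 to compound 3 (0.12 log units; within the scatter) and a 1.7-fold higher number from compound 2 to compound 3 (0.22 log units; within the scatter).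

Compound 4 `Clc1ccc(-c2ccc(Cn3nnc4ccccc43)cc2)c(Cl)c1` takes one more step of this kind: chloro in place of fluoro on an aromatic carbon. The only earlier exchange of chloro for fluoro among these compounds was a 1.7-fold higher number from compound 2 to compound 3 (0.22 log units; within the scatter), a step that stayed within the scatter. On that basis the coming step is expected to stay small, a 1.3-fold higher number from compound 3 to compound 4 (0.10 log units; within the scatter). Compound 4 is therefore estimated at 150 nM, with a range from 70 nM to 320 nM.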

Compound 4, half-maximal effective concentration: 79 nM
Compound 4: the middle estimate sits 1.9-fold (0.28 log units) above what was measured, and the stated range covers the measured number.
By their numbers in this assay, from the lowest: compounds 2, 4, 3 and 1 (each within the scatter of the next, the first and the last beyond it).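

The same exchange of fluoro for chloro, here on the carbon para to a large group and meta to a chloro group, now points the opposite way from the earlier exchange (a 1.5-fold lower number from compound 3 to compound 4 (0.17 log units; within the scatter)), and neither step lies beyond the scatter, so no direction can be assigned to it. Going from 2,4-difluorophenyl to 2,4-dichlorophenyl also stays within the scatter (a 1.1-fold higher number from compound 2 to compound 4 (0.05 log units; within the scatter)), and so does the step from plain phenyl to 2,4-dichlorophenyl (a 2.0-fold lower number from compound 1 to compound 4 (0.29 log units; within the scatter)), unlike the step from plain phenyl to 2,4-difluorophenyl. Nothing available explains these small differences.

The outer ring shown here carries only fluoro and chloro groups. From the compounds shown here alone, whether a methoxy group, a nitrile or an amine at this position would move the number beyond the scatter remains open.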